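This account rests on a few compounds, and the source may have more. Where it says the series, first, only, none or still open, it means among the compounds named here.

Measured in a functional assay on HCT-116 cells (Homo sapiens) for antiproliferative activity, read by MTT assay, with a stated time of 24 h; on this read-out higher numbers stand for weaker inhibition and lower numbers for stronger inhibition:
- compound 1 `C#CCOc1ccc2c(=O)c(-c3cc(OC)c(OC)cc3OC)coc2c1`: 8050 nM
- compound 2 `COc1cc(OC)c(-c2coc3cc(OCc4ccccc4)ccc3c2=O)cc1OC`: 2280 nM
- compound 3 `COc1cccc(C(=O)Oc2ccc3c(=O)c(-c4cc(OC)c(OC)cc4OC)coc3c2)c1`: > 10000 nM, a limit and not a number

Compound 3 stands at the limit of > 10000 nM in this assay, at which 1 of the 3 values shown sits. Compound 4 `COc1cc(OC)c(-c2coc3cc(OCc4ccccc4F)ccc3c2=O)cc1OC` differs from it by one change, 2-fluorobenzyl in place of (3-methoxyphenyl)carbonyl on an oxygen on an aromatic ring.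

The measured step that bears most directly runs the opposite way, with (3-methoxyphenyl)carbonyl entering in place of benzyl: an at least 4.3-fold higher number from compound 2 to compound 3 (0.64 log units; beyond the scatter). A second step, with phenyl in place of ethynyl, also favours the benzyl compound: a 3.5-fold lower number from compound 1 to compound 2 (0.55 log units; beyond the scatter). The remaining step says little, since its floor lies within the scatter: an at least 1.2-fold higher number from compound 1 to compound 3 (0.09 log units; that floor lies within the scatter).

Going by the values given here, no measured compound carries the fluorine, so the plain benzyl of compound 2, at 2280 nM, is the best guide. A step of at least modest size towards lower numbers, meaning stronger inhibition, is therefore expected in this assay. The expected step is an at least 4.5-fold lower number from compound 3 to compound 4 (0.65 log units; beyond the scatter). For compound 4 the estimated value is 2200 nM, with an expected range of 800 nM to 6000 nM.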

Compound 4, half-maximal inhibitory concentration: 2900 nM
For compound 4 the middle estimate is 1.3-fold (0.12 log units) below the measured one, and the stated range covers the measured number.
By their numbers in this assay, from the lowest: compounds 2 and 4 (each within the scatter of the next); then compound 1. At a limit, above all of these: compound 3.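

In this assay, the 2-fluorobenzyl group on an oxygen on an aromatic ring gives a clear gain over the (3-methoxyphenyl)carbonyl group: an at least 3.4-fold lower number from compound 3 to compound 4 (0.53 log units; beyond the scatter). Compound 3 stands at a limit and not at a number, so that step is only a floor: the limit of > 10000 nM in this assay, at which 1 of the 4 values shown sits. The benzyl group also accepts this one fluorine without a change beyond the scatter, a 1.3-fold higher number from compound 2 to compound 4 (0.10 log units; within the scatter), and compound 4 keeps an advantage over the propargyl ether, a 2.8-fold lower number from compound 1 to compound 4 (0.44 log units; beyond the scatter).

The compounds shown leave open how a 2-chlorobenzyl group, a benzyl group bearing a carboxylic acid, or a longer chain ending in an amine would read on that oxygen in this assay. They also do not separate the carbonyl from the methoxy group of compound 3, which a plain benzoyl group on that oxygen would do.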